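The compounds below may be only part of what the source reports. "The series", "measured", "known", "first", "only" and "open" are said of these compounds alone.

Compound 1 `CCOC(=O)CCCCCOc1cccc(CN(C(=O)c2ccc(-c3cccc(NC(C)=O)c3)cc2)C(C)C)c1` in an ADME assay on BJ cells (Homo sapiens) for cytotoxicity, read by CellTiter-Glo and resazurin assay, with a stated time of 72 h (a lower number here means that less compound is needed, a higher number that more compound is needed for the effect), gives > 26000 nM, a limit of the assay.
Compound 2 `CCOC(=O)CCCCCOc1cccc(CN(C(=O)c2ccc(-c3cccc(OC(C)C)c3)cc2)C(C)C)c1` in this assay gives > 26000 nM, a limit of the assay.
Compound 3 `CCOC(=O)CCCCCOc1cccc(CN(C(=O)c2ccc(-c3cccc(OCc4ccccc4)c3)cc2)C(C)C)c1` in this assay gives > 26000 nM, a limit of the assay.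

Compound 3 therefore stands where every value shown stands, at the limit of > 26000 nM in this assay, at which 3 of the 3 values shown sit. Compound 4 `CCOC(=O)CCCCCOc1cccc(CN(C(=O)c2ccc(-c3cccc(C(F)(F)F)c3)cc2)C(C)C)c1` differs from compound 3 by trifluoromethyl in place of benzyloxy on an aromatic carbon. The measured steps on that aromatic carbon, a step that the two limits leave unreadable from compound 1 to compound 2, a step that the two limits leave unreadable from compound 1 to compound 3 and a step that the two limits leave unreadable from compound 2 to compound 3, are all unreadable, since each end sits on the limit. Within the data shown here, no measured step separates one group on that carbon from another. For compound 4 the expected step in this assay is a step that the limit leaves unreadable from compound 3 to compound 4. Compound 4 is estimated at 30000 nM, between 12000 nM and 100000 nM, with a limit rather than a number the most likely outcome.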

Compound 4, half-maximal effective concentration: < 1.3 nM
Compound 4 ended at the assay's limit (the forecaster's own chance of this, stated with the estimate: 85%); at least 23000-fold (4.36 log units) between middle value and limit.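

At this aromatic carbon, the swaps among acetamido, isopropoxy and benzyloxy cannot be read, since all three compounds sit at a limit, so the position looked silent in this assay. Trifluoromethyl changes that, giving an at least 20000-fold lower number from compound 3 to compound 4 (4.30 log units; beyond the scatter), an at least 20000-fold lower number from compound 2 to compound 4 (4.30 log units; beyond the scatter) and an at least 20000-fold lower number from compound 1 to compound 4 (4.30 log units; beyond the scatter). Compound 4 also sits at a limit, at the opposite end of the range: the limit of < 1.3 nM in this assay, at which 1 of the 4 values shown sits.

As far as these compounds go, how far the true value of compound 4 lies past its limit remains open. So does whether another group on this carbon, such as a nitrile or a chlorine atom, would give a similar result.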